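The source may report more compounds than this note shows. Statements on the series, on what has been measured and on what is new or still open speak of the compounds shown alone.

Working notes on the series, step from compound 3 to compound 4.

Going by the values given here, compound 3 `CN(C)C(=O)C1CCN(c2cnccc2-n2cc(Br)cn2)CC1` holds the lowest number of the three measured so far: in an assay on HEK293F cells for inhibition of cholesterol 24-hydroxylase (Homo sapiens), read by trypan blue exclusion, with stated times of 15 min and 5 h (on this read-out lower numbers stand for stronger inhibition and higher numbers for weaker inhibition), compound 3 gives 9.5 nM. Compound 1 `CN(C)C(=O)C1CCN(c2cnccc2-n2cccn2)CC1` gives 48 nM in this assay, and compound 2 `Cc1ccn(-c2ccncc2N2CCC(C(=O)N(C)C)CC2)n1` gives 1100 nM. The steps among them are a 5.1-fold lower number from compound 1 to compound 3 (0.70 log units; beyond the scatter), a 23-fold higher number from compound 1 to compound 2 (1.36 log units; beyond the scatter) and a 120-fold lower number from compound 2 to compound 3 (2.06 log units; beyond the scatter).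

The change to compound 4 `Cc1cnc(-c2ccncc2N2CCC(C(=O)N(C)C)CC2)s1` is 5-methyl-1,3-thiazol-2-yl in place of 4-bromo-1H-pyrazol-1-yl on an aromatic carbon. Among the compounds with values here, no measured step swaps one five-membered ring for another of a different kind, so the bearing is indirect. The step of a 5.1-fold lower number from compound 1 to compound 3 (0.70 log units; beyond the scatter) shows that the bromo on the ring that leaves was worth a modest gain, which compound 4 gives up. From the compounds shown here alone, the step of a 23-fold higher number from compound 1 to compound 2 (1.36 log units; beyond the scatter) shows that a methyl on that ring, in the position it held, cost a large amount; whether a methyl on the ring that enters behaves alike is unknown. On this basis a step toward higher numbers in this assay is expected, of size a 16-fold higher number from compound 3 to compound 4 (1.20 log units; beyond the scatter), with wide uncertainty in both directions.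

For compound 4 in this assay the expected number is 150 nM, in a range from 30 nM to 800 nM.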

Compound 4, half-maximal inhibitory concentration: 12 nM
Estimate against measurement, compound 4: 13-fold (1.10 log units) above; the whole stated range lies above it.
By their numbers in this assay, from the lowest: compounds 3 and 4 (each within the scatter of the next); then compound 1; then compound 2.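

At this place, on an aromatic carbon of a six-membered aromatic ring with 1 nitrogen, opposite the ring nitrogen, the 4-bromo-1H-pyrazol-1-yl group is not needed for a low number: in this assay the exchange for 5-methyl-1,3-thiazol-2-yl leaves the two compounds indistinguishable (a 1.3-fold higher number from compound 3 to compound 4 (0.10 log units; within the scatter)). The low number also does not depend on a bromo, since the exchange of 1H-pyrazol-1-yl for the 5-methyl-1,3-thiazol-2-yl group still gives a modest step (a 4.0-fold lower number from compound 1 to compound 4 (0.60 log units; beyond the scatter)). A methyl on the five-membered ring therefore does not in itself carry the cost seen with 3-methyl-1H-pyrazol-1-yl, as the step between the two methyl-bearing groups is large (a 92-fold lower number from compound 2 to compound 4 (1.96 log units; beyond the scatter)).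

The compounds shown leave open what the methyl contributes within 5-methyl-1,3-thiazol-2-yl, and how an unsubstituted 1,3-thiazol-2-yl, a bromo on that ring or an amine there would compare. The data at hand offer no measurement that accounts for any of these steps.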